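Working notes: bromo to fluoro on the benzyl arm

This account rests on a few compounds, and the source may have more. Where it says the series, first, only, none or still open, it means among the compounds named here.

Measured so far:
compound 1 `O=C(/C=C/c1ccc(OCc2cn(Cc3ccccc3)nn2)cc1)c1ccc(Br)cc1`; in a functional assay on MIA PaCa-2 cells (Homo sapiens) for inhibition, read by MTT assay, with a stated time of 48 h, tested at 10 uM (a lower number here means less inhibition of growth, a higher number more inhibition of growth at the concentration tested), compound 1 gives 44%
compound 2 `O=C(/C=C/c1ccc(OCc2cn(Cc3ccc(Br)cc3)nn2)cc1)c1ccc(Br)cc1`; in this assay compound 2 gives 29%

Going by the values given here, compound 2 holds the lower of the two numbers; the only measured step, a number 15 percentage points lower from compound 1 to compound 2 (beyond the scatter), is modest but beyond the scatter. Compound 3 `O=C(/C=C/c1ccc(OCc2cn(Cc3cccc(F)c3)nn2)cc1)c1ccc(Br)cc1` arises from compound 2 by 3-fluorophenyl in place of 4-bromophenyl on a saturated chain carbon bound to an aromatic nitrogen. That step bears on the change only in part: the bromo of compound 2 leaves, yet a fluorine enters rather than a return to hydrogen. Compound 3 is therefore expected to move partway back, a step of a number 9 percentage points higher from compound 2 to compound 3 (within the scatter), with an estimate of 38% (range 24% to 52%).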

Compound 3, percent growth inhibition at one concentration: 34%
Compound 3: middle estimate off by 4 percentage points, on the high side; measured number inside the range.
By their numbers in this assay, from the lowest: compounds 2, 3 and 1 (each within the scatter of the next, the first and the last beyond it).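

In this assay, 3-fluorophenyl in place of 4-bromophenyl on a saturated chain carbon bound to an aromatic nitrogen gives a number 5 percentage points higher from compound 2 to compound 3 (within the scatter), while adding a fluorine gives a number 10 percentage points lower from compound 1 to compound 3 (within the scatter). Compound 3 therefore cannot be separated from either compound 1 or compound 2, although those two lie beyond the scatter of each other. A fluorine on this arm thus leaves no step beyond the scatter, unlike the bromo of compound 2.

Going by these compounds, how an amine or a carboxylic acid in place of the 3-fluorophenyl would read in this assay remains open. No measurement at hand gives a reason for these steps.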